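A few compounds are considered here, and "the series" means these few. Any claim that something is new, unique, unknown or untested is made for them only; others in the source may bear on it.

In an ADME assay on L02 cells (Homo sapiens) for inhibition, read by CCK-8 assay, with a stated time of 48 h (a lower number here means a stronger inhibitor of growth, a higher number a weaker inhibitor of growth), compound 1 `Cc1ccccc1Nc1nc(Nc2ccccc2)ncc1Cl` reads > 100000 nM, which is a limit of the assay and not a number. Among the compounds with values here, compound 2 `CN1CCN(c2ccc(Nc3ncc(Cl)c(NCc4ccc(F)cc4)n3)nc2)CC1` gives 39700 nM, the only actual number so far. Compound 3 `Cc1cccc(Nc2nc(Nc3ccc(N4CCN(C)CC4)cn3)ncc2Cl)c1` carries 3-methylphenyl in place of 4-fluorobenzyl on a nitrogen on an aromatic ring. Within the data shown here, no measured pair of compounds shows this change. The expected step of a 1.1-fold lower number from compound 2 to compound 3 (0.05 log units; within the scatter) is therefore small, within the usual scatter of the assay, with no firm direction. The estimated value for compound 3 is 35000 nM, with an expected range of 12000 nM to 100000 nM.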

Compound 3, concentration for 50% growth inhibition: 6080 nM
The estimate for compound 3 lay 5.8-fold (0.76 log units) above the measured number, outside the stated range (below it).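

In this assay, the group on this nitrogen clearly matters: 3-methylphenyl in place of 4-fluorobenzyl gives a 6.5-fold lower number from compound 2 to compound 3 (0.81 log units; beyond the scatter). Both groups carry a six-membered carbon ring, so even this close swap moves the reading beyond the scatter. Within the data shown here, compound 1 adds no second step, since its reading is a limit of the assay and not a number: the limit of > 100000 nM in this assay, at which 1 of the 3 values shown sits.

The swap changes benzyl to phenyl and fluorine to methyl together, so the two changes cannot be separated here. A 4-fluorophenyl or 3-methylbenzyl group on the same nitrogen would separate them.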